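The compounds below may be only part of what the source reports. "The series", "measured", "known", "first", "only" and "open" are said of these compounds alone.

In a functional assay on MCF7 cells (Homo sapiens) for cytotoxicity, read by MTT assay, with a stated time of 72 h, tested at 100 uM (a higher number here means more inhibition of growth at the concentration tested, a lower number less inhibition of growth), the three measured compounds gave these numbers:

Compound 1 `Cc1ccnc(/C(N)=N/NC(=S)N2CCCCC2)c1`: 80.1%
Compound 2 `Cc1cccc(/C(N)=N/NC(=S)N2CCCC2)n1`: 61.8%
Compound 3 `Cc1ccnc(/C(N)=N/NC(=S)N2CCN(c3ccccn3)CC2)c1`: 63.4%

Compound 3 stands second highest of the three numbers in this assay. Its nearest neighbour is compound 2, whose number lies lower by an amount that is within the scatter of repeated measurements, so the two cannot be told apart. The furthest is compound 1, whose number lies higher by an amount beyond the scatter.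

Compound 4 `N/C(=N\NC(=S)N1CCN(c2ccccn2)CC1)c1ccccn1` has not yet been measured in this assay. It differs from compound 3 in one place: hydrogen in place of methyl on an aromatic carbon. Taken one bond further out, 4-methylpyridin-2-yl becomes pyridin-2-yl.

For the measured compounds named here, no step between measured compounds shows what the loss of this methyl does. With only a hydrogen atom entering, the account expects the step of a number 5.4 percentage points lower from compound 3 to compound 4 (within the scatter) to be small and not beyond the scatter, leaning if anything slightly downward. Compound 4 is therefore estimated at 58% in this assay, with a range from 40% to 75%.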

Compound 4, percent growth inhibition at one concentration: 68.3%
The estimate for compound 4 lay 10.3 percentage points below the measured number; the range from low to high includes it.
By their numbers in this assay, from the lowest: compounds 2, 3 and 4 (each within the scatter of the next); then compound 1.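

With 4-methylpyridin-2-yl replaced by pyridin-2-yl, the change reads as a number 4.9 percentage points higher from compound 3 to compound 4 (within the scatter) in this assay. For the compounds shown here, this is the first direct reading at this position, and it shows that the methyl opposite the ring nitrogen can give way to hydrogen with no change that can be told from the scatter, so growth inhibition at the concentration tested does not depend on this methyl in this pair. The compounds shown offer no measurement that would explain this result.

As far as these compounds go, whether a larger group on this carbon, such as an amine, a methoxy group or a carboxylic acid, would also leave the number within the scatter remains open. So does whether the methyl is equally dispensable when the rest of the molecule is that of compound 1.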